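The compounds below may be only part of what the source reports. "The series", "measured", "known", "first", "only" and "open" are said of these compounds alone.

Compound 1 `O=C(Nc1ccc(Oc2ccnc3[nH]ccc23)cc1)c1cc2cccnc2n(-c2ccccc2)c1=O` is the reference point of this small set. In a functional assay on NCI-H460 cells (Homo sapiens) for antiproliferative activity, read by MTT assay, with a stated time of 72 h (a lower number here means a stronger inhibitor, a higher number a weaker inhibitor), compound 1 gives 380 nM, the lowest of the two numbers that were recorded. Compound 2 `COc1ccc(-n2c(=O)c(C(=O)Nc3ccc(Oc4ccnc5[nH]ccc45)cc3)cc3cccnc32)cc1` differs from compound 1 only by methoxy in place of hydrogen on an aromatic carbon, and in this assay compound 2 gives 960 nM, a change of a 2.5-fold higher number from compound 1 to compound 2 (0.40 log units; beyond the scatter). Compound 3 `O=C(Nc1ccc(Oc2ccnc3[nH]ccc23)cc1)c1cc2cccnc2n(-c2ccc(Br)cc2F)c1=O` was made, but in this assay compound 3 is entered as "not determined" (no result reported), so no result was reported for it.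

Compound 4 `O=C(Nc1ccc(Oc2ccnc3[nH]ccc23)cc1)c1cc2cccnc2n(-c2ccc(C(F)(F)F)cc2Cl)c1=O` is built from compound 1 by the change (2-chloro-4-(trifluoromethyl)phenyl in place of phenyl on an aromatic nitrogen). Among the compounds with values here, no measured step touches the group on the aromatic nitrogen; the only step available, from compound 1 to compound 2, concerns a different part of the molecule and raised the number modestly. With nothing that bears directly on the change, the expectation is a number close to that of compound 1, with a slight lean toward a higher value and a wide range. Compound 4 is therefore estimated at 600 nM, between 150 nM and 2500 nM, an expected step of a 1.6-fold higher number from compound 1 to compound 4 (0.20 log units; within the scatter).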

Compound 4, half-maximal inhibitory concentration: 1950 nM
Compound 4: the middle estimate sits 3.3-fold (0.51 log units) below what was measured, and the stated range covers the measured number.
By their numbers in this assay, from the lowest: compound 1; then compound 2; then compound 4.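

On the group carried by the aromatic nitrogen, replacing phenyl with 2-chloro-4-(trifluoromethyl)phenyl gives a 5.1-fold higher number from compound 1 to compound 4 (0.71 log units; beyond the scatter) in this assay, so this position tolerates the larger group but with weaker activity. Replacing 4-methoxyphenyl with the same group gives a 2.0-fold higher number from compound 2 to compound 4 (0.31 log units; beyond the scatter), which means that both substituted rings with a number, in compound 2 and compound 4, read higher than the plain phenyl of compound 1, with no numbered compound going against this. No measurement here explains the rise.

The chlorine and the trifluoromethyl enter together, so their separate contributions cannot be told apart, and compound 3 adds no number. From the compounds shown here alone, it remains open whether an amine or a carboxylic acid on this ring, or a cyclohexyl in place of phenyl, would give a number lower than that of compound 1.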